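This account rests on a few compounds, and the source may have more. Where it says the series, first, only, none or still open, it means among the compounds named here.

In a functional assay on MCF7 cells (Homo sapiens) for antiproliferative activity (a higher number here means a weaker inhibitor, a lower number a stronger inhibitor), compound 1 (`Nc1n[nH]c(N)c1/N=N/c1cccc2c1CCCC2`) gives 81000 nM and compound 2 (`Nc1n[nH]c(N)c1/N=N/c1cccc([N+](=O)[O-])c1`) gives 65000 nM so that the two numbers lie within the scatter of each other. Compound 3 (`Nc1n[nH]c(N)c1/N=N/c1cccc(O)c1`) has not yet been measured. It differs from compound 2 by hydroxy in place of nitro on an aromatic carbon with hydroxy in place of nitro on an aromatic carbon. For the measured compounds named here, no measured pair isolates a single change, so the data give no direct guide to this one. In this assay no step beyond the scatter is expected, and the estimated 1.3-fold lower number from compound 2 to compound 3 (0.11 log units; within the scatter) stays inside it. Compound 3 is expected at 50000 nM with an estimated range of 15000 nM to 130000 nM for this measurement.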

Compound 3, half-maximal inhibitory concentration: > 100000 nM
Compound 3 was reported as a limit; the forecaster's own chance of this, stated with the estimate: 12%; middle value at least 2.0-fold (0.30 log units) from the limit.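

In this assay compound 3 gives > 100000 nM, which is a limit of the assay and not a number. Hydroxy in place of nitro on an aromatic carbon, meta to a group of 9 heavy atoms, provides the first single-place comparison here, with an at least 1.5-fold higher number from compound 2 to compound 3 (0.18 log units; that floor lies within the scatter). From the compounds shown here alone, only the floor of that step is known, so its true size remains unknown, but hydroxy at this position gives no stronger inhibitor than nitro. Going by these compounds, whether an amine or a carboxylic acid at this position would give a lower number remains open, as does the actual value of compound 3.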